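The source may report more compounds than this note shows. Statements on the series, on what has been measured and on what is new or still open speak of the compounds shown alone.

Measured so far:
compound 1 `O=C(O)c1cccc(OCc2ccc(Oc3ccccc3)cc2)c1` — > 10000 nM
compound 2 `CCOc1cccc(C(=O)Nc2cccc(C(=O)O)c2)c1` — 2350 nM

In an assay on isolated protein for agonist activity at Bile acid receptor (Homo sapiens), read by TR-FRET, with a stated time of 3 h, in the absence of a further agent (on this read-out higher numbers stand for an effect only at larger amounts of compound and lower numbers for an effect already at smaller amounts), compound 1 gives only (the limit of > 10000 nM in this assay, at which 1 of the 2 values shown sits), a limit rather than a number. In this assay compound 2 gives 2350 nM, the only number shown, and so it stands alone as the reference point. Compound 3 `O=C(O)c1cccc(NC(=O)c2cccc(OCC3CC3)c2)c1` differs from compound 2 by cyclopropyl in place of methyl on a saturated chain carbon bound to an oxygen on an aromatic ring. Among the compounds with values here, no step between measured compounds covers this change, so the expected step from compound 2 to compound 3 is a 1.6-fold lower number from compound 2 to compound 3 (0.19 log units; within the scatter), a small gain close to the scatter. Compound 3 is thus estimated at 1500 nM, within 500 nM to 5000 nM.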

Compound 3, half-maximal effective concentration: 1260 nM
Beside the measured number, compound 3's estimate is 1.2-fold (0.08 log units) above it, within the range that was stated.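

Cyclopropyl in place of methyl on a saturated chain carbon bound to an oxygen on an aromatic ring gives, in this assay, a 1.9-fold lower number from compound 2 to compound 3 (0.27 log units; within the scatter). Within the data shown here, this is the first step that can be read at this position, and it shows that ethoxy can be exchanged for the larger cyclopropylmethoxy while the read-out stays a number within the scatter of the one before it. Nothing measured here accounts for this step.

On these data alone, whether an amine or a longer chain at this place would move the number beyond the scatter stays open. So does whether the same exchange would give a step of this size on another core.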